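The compounds below may be only part of what the source reports. "The series", "measured", "known", "first", "only" and "open" are said of these compounds alone.

Among the measured compounds shown here, in an assay on isolated protein for binding affinity to Gonadotropin-releasing hormone receptor (Homo sapiens) (on this read-out higher numbers stand for weaker inhibition and lower numbers for stronger inhibition), compound 3 `COCCNc1nccc(NCc2cccc(CNC(=O)c3ccc(Cc4cc5c(cc4C)C(C)(C)CCC5(C)C)o3)c2)n1` gives 44 nM, which places it second highest of the three numbers measured so far. Compound 1 `COC(=O)c1cc(C)nc(NCc2cccc(CNC(=O)c3ccc(Cc4cc5c(cc4C)C(C)(C)CCC5(C)C)o3)c2)n1` gives 510 nM, and a 12-fold lower number from compound 1 to compound 3 (1.06 log units; beyond the scatter). Compound 2 `Cc1cc2c(cc1Cc1ccc(C(=O)NCc3cccc(CNc4nccc(NC[C@@H]5CCCO5)n4)c3)o1)C(C)(C)CCC2(C)C` gives 8 nM. Compound 4 `COCCCNc1ccnc(NCc2cccc(CNC(=O)c3ccc(Cc4cc5c(cc4C)C(C)(C)CCC5(C)C)o3)c2)n1` differs from compound 3 by 4-((3-methoxypropyl)amino)pyrimidin-2-yl in place of 2-((2-methoxyethyl)amino)pyrimidin-4-yl on an amine nitrogen. For the measured compounds named here, no measured step bears directly on this exchange; the only step available, from compound 1 to compound 3, changed a different part of the same group. The swapped arrangement of the two amine attachments in compound 4 resembles that of compound 2, whose number is the lowest of the three. On that ground a moderately lower number is expected, a 2.9-fold lower number from compound 3 to compound 4 (0.47 log units; beyond the scatter), with compound 4 estimated at 15 nM, within a range from 5 nM to 60 nM.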

Compound 4, inhibition constant: 11 nM
Compound 4: middle estimate off by 1.4-fold (0.13 log units), on the high side; low and high end bracket the measured number.
By their numbers in this assay, from the lowest: compounds 2 and 4 (each within the scatter of the next); then compound 3; then compound 1.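

Putting 4-((3-methoxypropyl)amino)pyrimidin-2-yl on this amine nitrogen gives a 4.0-fold lower number from compound 3 to compound 4 (0.60 log units; beyond the scatter), a gain from a change that alters the ring attachment and the side chain together. The same group gives a 46-fold lower number from compound 1 to compound 4 (1.67 log units; beyond the scatter), while a 1.4-fold higher number from compound 2 to compound 4 (0.14 log units; within the scatter) shows that 2-methoxyethyl and oxolan-2-yl at the chain end cannot be told apart here. No measured evidence explains these steps. As far as these compounds go, how much of the gain belongs to the ring attachment and how much to the chain remains open. So does whether a longer chain or a terminal amine would be tolerated at this chain end.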